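A few compounds are considered here, and "the series" means these few. Any claim that something is new, unique, unknown or untested is made for them only; others in the source may bear on it.

Measured compounds:
compound 1 `O=C(NO)c1ccc(CNCc2nc(-c3ccccc3)no2)cc1`, 200 nM in an assay on isolated protein for inhibition of histone deacetylase 8 (Homo sapiens), read by fluorescence, with a stated time of 20 min; on this read-out higher numbers stand for weaker inhibition and lower numbers for stronger inhibition
compound 2 `O=C(NO)c1ccc(CNCc2nc(-c3ccc(Cl)cc3)no2)cc1`, 350 nM

Among the measured compounds shown here, compound 2 holds the higher of the two numbers, but its only neighbour, compound 1, sits within the usual scatter: a 1.8-fold higher number from compound 1 to compound 2 (0.24 log units; within the scatter). Compound 3 `O=C(NO)c1ccc(CNCc2nc(-c3ccc([N+](=O)[O-])cc3)no2)cc1` differs from compound 2 by nitro in place of chloro on an aromatic carbon. For the measured compounds named here, the one measured step at this position, a 1.8-fold higher number from compound 1 to compound 2 (0.24 log units; within the scatter), stayed within the scatter, so no shift beyond the scatter is expected in this assay: the step of no change at the digits printed from compound 2 to compound 3 (within the scatter) is the estimate. Compound 3 is therefore expected near 350 nM, in a range from 150 nM to 800 nM.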

Compound 3, half-maximal inhibitory concentration: 380 nM
Compound 3: middle estimate off by 1.1-fold (0.04 log units), on the low side; the measured number falls inside the stated range.
By their numbers in this assay, from the lowest: compounds 1, 2 and 3 (each within the scatter of the next).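

Across this assay this position now holds hydrogen, chloro and nitro, and both new steps (a 1.1-fold higher number from compound 2 to compound 3 (0.04 log units; within the scatter)) and (a 1.9-fold higher number from compound 1 to compound 3 (0.28 log units; within the scatter)) stay within the scatter. Nitro, with three heavy atoms and two hydrogen-bond acceptors, therefore cannot be told apart here from a single chlorine atom or from hydrogen. No supporting data explain this result.

Going by these compounds, whether the position tolerates every group remains open: an amine, a carboxylic acid or a longer carbon chain in the same place could still move the number beyond the scatter.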